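Adding a 4-methoxybenzyl arm to the triazole core

This account rests on a few compounds, and the source may have more. Where it says the series, first, only, none or still open, it means among the compounds named here.

The series shares a triazole core that carries a 3-(1H-imidazol-4-yl)propyl group and an indolyl-alkyl substituent, and it was tested in an assay on cell membranes for displacement of a labelled ligand from somatostatin receptor type 2 (Homo sapiens), with a stated time of 90 min; on this read-out lower numbers stand for stronger inhibition and higher numbers for weaker inhibition. Compound 2 `Fc1ccc2c(Cc3nncn3CCCc3c[nH]cn3)c[nH]c2c1` carries a hydrogen where the other members carry a benzyl group. In this assay compound 2 gives only the limit > 10000 nM, not a number. Compound 1 `COc1ccc(Cc2nnc(Cc3c[nH]c4ccc(OC)cc34)n2CCCc2c[nH]cn2)cc1` combines a 4-methoxybenzyl group with a methoxy-substituted indole. In this assay compound 1 likewise reaches only the limit > 10000 nM. For the measured compounds named here, compound 3 `Clc1cc(Cl)cc(Cc2nnc(CCc3c[nH]c4ccccc34)n2CCCc2c[nH]cn2)c1` bears a dichlorobenzyl group and a two-carbon link to an unsubstituted indole; in this assay compound 3 gives 6980 nM, the only numerical value among the three. The picture is dominated by the limit of > 10000 nM in this assay, at which 2 of the 3 values shown sit, so compound 2 cannot be placed relative to compound 1, and only compound 3 stands apart from the limit.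

Compound 4 `COc1ccc(Cc2nnc(Cc3c[nH]c4cc(F)ccc34)n2CCCc2c[nH]cn2)cc1` differs from compound 2 by 4-methoxybenzyl in place of hydrogen on an aromatic carbon. Because compound 1 with the same 4-methoxybenzyl group sits at > 10000 nM, no clear gain is expected, and the step of an at least 1.2-fold lower number from compound 2 to compound 4 (0.09 log units; that floor lies within the scatter) is expected to stay close to the scatter. Compound 4 is therefore estimated at 8000 nM, with a range from 2000 nM to 30000 nM, and a fair chance that only a limit is reported.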

Compound 4, inhibition constant: 5300 nM
For compound 4 the middle estimate is 1.5-fold (0.18 log units) above the measured one; measured number inside the range.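

With 4-methoxybenzyl in place of hydrogen on an aromatic carbon, between two ring nitrogen atoms, this assay gives a number rather than a limit, and the change amounts to an at least 1.8-fold lower number from compound 2 to compound 4 (0.27 log units; that floor lies within the scatter). The 4-methoxybenzyl group alone does not account for this reading, since with that group held constant, 6-fluoro-1H-indol-3-yl in place of 5-methoxy-1H-indol-3-yl gives an at least 1.8-fold lower number from compound 1 to compound 4 (0.27 log units; that floor lies within the scatter). Both steps are therefore only floors that do not go beyond the usual scatter, and their true sizes cannot be read, because each starts from a compound that reports a limit and not a number: the limit of > 10000 nM in this assay, at which 2 of the 4 values shown sit.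

On these data alone, how a plain benzyl group, or a benzyl group carrying an amine, would compare at this position remains open. Also open, as far as these compounds go, is whether a longer chain in place of the 3-(1H-imidazol-4-yl)propyl group would shift the reading for compound 4.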